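Trimethoxyphenyl pyrazole chalcones: a difluorophenyl variant

The compounds below may be only part of what the source reports. "The series", "measured", "known", "first", "only" and "open" are said of these compounds alone.

Of the compounds shown here, three from this series have been measured in a functional assay on HCC 2998 cells (Homo sapiens) for inhibition, read by sulforhodamine B assay, with a stated time of 48 h; on this read-out higher numbers stand for weaker inhibition of growth and lower numbers for stronger inhibition of growth. Compound 1 `COc1ccc(-c2cc(/C=C/C(=O)c3ccc(N)cc3)[nH]n2)cc1` gives 1830 nM. Compound 2 `COc1ccc(C(=O)/C=C/c2cc(-c3cc(OC)c(OC)c(OC)c3)n[nH]2)cc1` gives 1780 nM, and compound 3 `COc1cc(C(=O)/C=C/c2cc(-c3cc(OC)c(OC)c(OC)c3)n[nH]2)cc(OC)c1OC` gives 1830 nM. Compound 2 stands lowest of the three numbers, yet its gaps to compound 1 and to compound 3 both lie within the scatter of this assay, so the three values cannot be told apart.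

Compound 4 `COc1cc(-c2cc(/C=C/C(=O)c3ccc(F)c(F)c3)[nH]n2)cc(OC)c1OC` has not yet been measured. It differs from compound 2 in one place: 3,4-difluorophenyl in place of 4-methoxyphenyl on a carbonyl carbon. Since the three measured compounds, which carry different aryl groups on the carbonyl carbon and on the shared core, all sit at about the same value, the piece expects the step from compound 2 to compound 4 to be small, with no direction beyond the scatter, as a 1.1-fold higher number from compound 2 to compound 4 (0.05 log units; within the scatter). Compound 4 is therefore estimated at 2000 nM, within a range from 800 nM to 5000 nM.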

Compound 4, concentration for 50% growth inhibition: 3690 nM
Estimate against measurement, compound 4: 1.8-fold (0.27 log units) below, and the stated range covers the measured number.
By their numbers in this assay, from the lowest: compounds 2, 1, 3 and 4 (each within the scatter of the next, the first and the last beyond it).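

In this assay, among the compounds shown here, the aryl group on a carbonyl carbon now proves able to move the number: 3,4-difluorophenyl in place of 4-methoxyphenyl gives a 2.1-fold higher number from compound 2 to compound 4 (0.32 log units; beyond the scatter), the only step here that can be read. The step is modest and rests on this single pair. The change also takes away an oxygen and brings in two fluorines at once, so the effect of each cannot be separated, and nothing measured here accounts for the rise.

From the compounds shown here alone, it remains open whether a phenyl group carrying a single fluorine, a chlorine or a nitrile on that carbonyl carbon would give a number closer to compound 2 or to compound 4. Also open, going by these compounds, is whether 3,4-difluorophenyl would produce a similar step on the core of compound 1.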